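The source may report more compounds than this note shows. Statements on the series, on what has been measured and on what is new or still open speak of the compounds shown alone.

Of the compounds shown here, three sharing one core have been measured in a functional assay (aorta) with Rattus norvegicus as the target, in the presence of a further agent that is not named here; a lower number here means that less compound is needed, a higher number that more compound is needed for the effect. Compound 1 (`COC(=O)C1=C(C)N=C(C)/C(=C(/O)OC)C1c1cccc(OCc2nonc2C)c1`) gives 640 nM and compound 2 (`COC(=O)C1=C(C)N=C(C)/C(=C(/O)OC)C1c1cccc(OCc2c(C)no[n+]2[O-])c1`) gives 400 nM, two values within the scatter of each other. Compound 3 (`COC(=O)C1=C(C)N=C(C)/C(=C(/O)OC)C1c1cccc(OCc2nonc2C(N)=O)c1`) gives 3500 nM, the highest of the three numbers, which makes it the least potent of the set. The two gaps to it are a 5.5-fold higher number from compound 1 to compound 3 (0.74 log units; beyond the scatter) and an 8.8-fold higher number from compound 2 to compound 3 (0.94 log units; beyond the scatter).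

The next compound, compound 4 (`COC(=O)C1=C(C)N=C(C)/C(=C(/O)OC)C1c1cccc(OCc2c(C(N)=O)no[n+]2[O-])c1`), departs from compound 3 in a single place, on a saturated chain carbon bound to an oxygen on an aromatic ring. There, 4-carbamoyl-1,2,5-oxadiazol-3-yl gives way to a group with no common name: a group of 9 heavy atoms (3 carbon, 3 nitrogen, 3 oxygen; one five-membered aromatic ring with 3 hetero atoms) in place of a group of 8 heavy atoms (3 carbon, 3 nitrogen, 2 oxygen; one five-membered aromatic ring with 3 hetero atoms), on a saturated chain carbon bound to an oxygen on an aromatic ring.

Among the measured compounds shown here, the closest precedent is a 1.6-fold lower number from compound 1 to compound 2 (0.20 log units; within the scatter), a similar exchange of groups made with methyl on the ring rather than carbamoyl. For the measured compounds named here, this is the only such step available, and it did not leave the scatter. The larger steps to compound 3 involve the carbamoyl group, which compound 4 keeps. Little movement is therefore expected in this assay, and any shift would more likely be towards a lower number. The expected change is a 1.5-fold lower number from compound 3 to compound 4 (0.16 log units; within the scatter). For compound 4 the estimated value is 2400 nM, with an expected range from 900 nM to 5500 nM.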

Compound 4, half-maximal effective concentration: 1200 nM
For compound 4 the middle estimate is 2.0-fold (0.30 log units) above the measured one; measured number inside the range.
By their numbers in this assay, from the lowest: compounds 2, 1 and 4 (each within the scatter of the next, the first and the last beyond it); then compound 3.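

In this assay, the exchange on a saturated chain carbon bound to an oxygen on an aromatic ring now leaves the scatter with carbamoyl on the ring, as a 2.9-fold lower number from compound 3 to compound 4 (0.46 log units; beyond the scatter) shows, whereas with methyl on the ring the same kind of exchange, a 1.6-fold lower number from compound 1 to compound 2 (0.20 log units; within the scatter), stayed within it. Carbamoyl in place of methyl now has a second reading, a 3.0-fold higher number from compound 2 to compound 4 (0.48 log units; beyond the scatter), so the rise in the number seen earlier is not confined to one core, and the two readings agree: the same change on two cores in this assay, a 5.5-fold higher number (0.74 log units; beyond the scatter) from compound 1 to compound 3 and a 3.0-fold higher number (0.48 log units; beyond the scatter) from compound 2 to compound 4, 1.8-fold (0.26 log units) apart, within the scatter of two such steps. Taken together, the two changes amount to a 1.9-fold higher number from compound 1 to compound 4 (0.27 log units; within the scatter), so compound 4, with both carbamoyl and the group of 9 heavy atoms, remains within the scatter of compound 1.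

The compounds shown cover only methyl and carbamoyl on the five-membered ring, so it remains open how a nitrile, a carboxylic acid or an ethyl group there would read in this assay, and whether the exchange would then behave as it does with methyl or as it does with carbamoyl. They also leave open whether a longer chain in place of the single saturated carbon would keep these steps at the same size.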